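Cytotoxicity notes on the halovinyl nucleoside series

The source may hold more compounds than are shown below. What is called first, only, known or untested is meant among the compounds shown, and "the series" means these compounds.

Compound 3 `O=c1[nH]c(=O)n(C2C[C@@H](O)[C@@H](CO)O2)nc1/C=C/Cl` is read in a functional assay on Vero cells (Chlorocebus sabaeus) for cytotoxicity (on this read-out lower numbers stand for stronger inhibition and higher numbers for weaker inhibition), only as a limit, > 500 ug/mL. Compound 1 `O=c1[nH]c(=O)n(C2C[C@@H](O)[C@@H](CO)O2)nc1/C=C/Br` gives a number in this assay, 355 ug/mL. Compound 2 `O=c1[nH]c(=O)n(C2C[C@@H](O)[C@@H](CO)O2)nc1/C=C(\F)Br` likewise returns only a limit, > 500 ug/mL. The measured steps are small or unreadable: an at least 1.4-fold higher number from compound 1 to compound 3 (0.14 log units; that floor lies within the scatter), an at least 1.4-fold higher number from compound 1 to compound 2 (0.14 log units; that floor lies within the scatter), and a step that the two limits leave unreadable from compound 2 to compound 3. That the two steps away from compound 1 can only be given as floors is due to the limit of > 500 ug/mL in this assay, at which 2 of the 3 values shown sit.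

The next compound, compound 4 `CS/C=C/c1nn(C2C[C@@H](O)[C@@H](CO)O2)c(=O)[nH]c1=O`, differs from compound 3 by methylsulfanyl in place of chloro on a double-bonded chain carbon bound to a double-bonded chain carbon. Within the data shown here, none of the measured steps touches a methylsulfanyl group; the steps seen so far exchange one halogen on the double-bonded chain carbon for another, or add a fluorine to it, and none of them moves the read-out beyond the scatter. On that basis the step from compound 3 to compound 4 is expected to be an at least 1.1-fold lower number from compound 3 to compound 4 (0.07 log units; that floor lies within the scatter), which amounts to no change that the assay could resolve. Compound 4 is therefore estimated at 420 ug/mL in this assay, within a range from 200 ug/mL to 500 ug/mL, with a fair chance that it too is reported only as a limit.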

Compound 4, concentration for 50% inhibition: 420 ug/mL
The estimate for compound 4 equals the measured number at the digits printed; the measured number falls inside the stated range.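

Compound 4 brings the first group other than a halogen to the double-bonded chain carbon bound to a double-bonded chain carbon, and its comparison with compound 1 is the only one in the series with a number at both ends: a 1.2-fold higher number from compound 1 to compound 4 (0.07 log units; within the scatter) in this assay. The other two steps, an at least 1.1-fold lower number from compound 3 to compound 4 (0.07 log units; that floor lies within the scatter) and an at least 1.1-fold lower number from compound 2 to compound 4 (0.07 log units; that floor lies within the scatter), remain floors due to the ceiling of the read-out: the limit of > 500 ug/mL in this assay, at which 2 of the 4 values shown sit. Methylsulfanyl therefore adds a sulfur-bearing group to the halogens at this position without any printed step beyond the scatter, although the floors do not fix how large those two steps are and the step between compound 2 and compound 3 cannot be read.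

The compounds shown leave open whether an amine, a carboxylic acid or a longer chain in place of methylsulfanyl on this carbon would give a number clearly apart from that of compound 1. They also leave open how compound 2 and compound 3 truly stand against compound 4, since only limits are available for the first two.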